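Chain extension on a pentylsulfanyl pyridine amide

The compounds below may be only part of what the source reports. "The series", "measured", "known", "first", "only" and "open" are said of these compounds alone.

Compound 1 `CCCOc1nc(C(C)(C)C)ccc1CNC(=O)C(C)c1ccc(NS(C)(=O)=O)c(F)c1` carries a propoxy group on its core; in an assay on cells for antagonist activity at transient receptor potential cation channel subfamily V member 1 (Homo sapiens), read by FLIPR and calcium flux, with a stated time of 6 min (on this read-out lower numbers stand for stronger inhibition and higher numbers for weaker inhibition), compound 1 gives 1.7 nM. Compound 2 `CC(C)COc1nc(C(C)(C)C)ccc1CNC(=O)C(C)c1ccc(NS(C)(=O)=O)c(F)c1` differs from it by methyl in place of hydrogen on a saturated chain carbon bound to two saturated chain carbons, and in this assay compound 2 gives 0.6 nM. That change produced a 2.8-fold lower number from compound 1 to compound 2 (0.45 log units; beyond the scatter). Compound 3 `CCCCCSc1nc(C(C)(C)C)ccc1CNC(=O)C(C)c1ccc(NS(C)(=O)=O)c(F)c1` differs from compound 1 by pentylsulfanyl in place of propoxy on an aromatic carbon, and in this assay compound 3 gives 3.1 nM; the step is a 1.8-fold higher number from compound 1 to compound 3 (0.26 log units; within the scatter), while against compound 2 it is a 5.2-fold higher number from compound 2 to compound 3 (0.71 log units; beyond the scatter).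

Compound 4 `CCCCCCSc1nc(C(C)(C)C)ccc1CNC(=O)C(C)c1ccc(NS(C)(=O)=O)c(F)c1` is unmeasured. It differs from compound 3 by methyl in place of hydrogen on a saturated chain carbon, five bonds along the chain from a sulfur. Going by the values given here, this is the same kind of change as the one from compound 1 to compound 2, but not the same: there the methyl entered on a saturated chain carbon bound to two saturated chain carbons, whereas here it enters on a saturated chain carbon five bonds along the chain from a sulfur. Because the earlier step of a 2.8-fold lower number from compound 1 to compound 2 (0.45 log units; beyond the scatter) rests on a different place, it is not taken as a direct guide; a smaller step is expected here, a 1.2-fold lower number from compound 3 to compound 4 (0.09 log units; within the scatter). Compound 4 is estimated at 2.5 nM, expected between 1 nM and 6.5 nM.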

Compound 4, inhibition constant: 1.5 nM
Estimate against measurement, compound 4: 1.7-fold (0.22 log units) above; the measured number falls inside the stated range.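

In this assay the added methyl gave a 2.1-fold lower number from compound 3 to compound 4 (0.32 log units; beyond the scatter), and the change lowered the number on both cores by a similar amount: the same change on two cores in this assay, a 2.8-fold lower number (0.45 log units; beyond the scatter) from compound 1 to compound 2 and a 2.1-fold lower number (0.32 log units; beyond the scatter) from compound 3 to compound 4, 1.4-fold (0.14 log units) apart, within the scatter of two such steps These two pairs show that the change carried over between the propoxy and pentylsulfanyl compounds, but the methyl entered at a different place in each pair, and two pairs do not show that the step would hold on other cores or at other chain carbons. Against the isobutoxy group, the hexylsulfanyl chain gave a 2.5-fold higher number from compound 2 to compound 4 (0.40 log units; beyond the scatter), while against the propoxy group it gave a 1.1-fold lower number from compound 1 to compound 4 (0.05 log units; within the scatter), which is within the scatter.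

The compounds shown leave open whether a longer chain on the sulfur would lower the number further or whether the step would shrink or reverse. They also leave open whether a branched chain such as isobutylsulfanyl, or an amine in place of the chain, would match compound 2.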